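Estimating Compound 4 from Three Measured Analogues

The source may report more compounds than this note shows. Statements on the series, on what has been measured and on what is new or still open speak of the compounds shown alone.

Compound 1, `CC(C)COC(=O)Nc1ccc([Se]C#N)cc1`, gives 27.1% in a physicochemical assay, with a stated time of 180 min, tested at 0.5 mg/mL; on this read-out lower numbers stand for less inhibition and higher numbers for more inhibition at the one concentration tested (going by the name of the read-out).
Compound 2, `CCCCCCOC(=O)Nc1ccc([Se]C#N)cc1`, gives in this assay only a limit, > 25%.
Compound 3, `CCOC(=O)Nc1ccc([Se]C#N)cc1`, gives 37% in this assay.

Of the three values in this assay, two are numbers and one is a limit. Compound 3 and compound 1 differ by a number 9.9 percentage points higher from compound 1 to compound 3 (within the scatter), a step that stays within the scatter, so the two cannot be told apart. The step that the limit leaves unreadable from compound 1 to compound 2 and the step that the limit leaves unreadable from compound 2 to compound 3 cannot be sized, since compound 2 is reported only as a limit (the limit of > 25% in this assay, at which 1 of the 3 values shown sits).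

Compound 4, `N#C[Se]c1ccc(NC(=O)OCc2ccccc2)cc1`, has not yet been measured. Its change from compound 3 is phenyl in place of methyl on a saturated chain carbon bound to an oxygen next to a carbonyl group. Every measured step touches the same place, and the only readable one, from compound 1 to compound 3, lies within the scatter. Going by the values given here, no step therefore argues for a shift beyond the scatter in this assay in either direction, and the expected step is a number 4 percentage points lower from compound 3 to compound 4 (within the scatter). The estimate for compound 4 in this assay is 33%, expected to fall between 20% and 48%.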

Compound 4, a percentage reported as inhibition, at one concentration (the size of the read-out at that concentration, not a potency): 3.7%
Compound 4: middle estimate off by 29.3 percentage points, on the high side; measured number below the stated range.
By their numbers in this assay, from the lowest: compound 4; then compounds 1 and 3 (each within the scatter of the next).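

Going by these compounds alone, at this position, the saturated chain carbon bound to an oxygen next to a carbonyl group, the read-out in this assay proves sensitive to the group attached, since phenyl in place of methyl gives a number 33.3 percentage points lower from compound 3 to compound 4 (beyond the scatter), whereas the one readable earlier step stayed within the scatter. The phenyl compound also separates from the other two chains, with a number 23.4 percentage points lower from compound 1 to compound 4 (beyond the scatter) and a number at least 21.3 percentage points lower from compound 2 to compound 4 (beyond the scatter). That last step gives only a minimum size, as compound 2 is reported as a limit: the limit of > 25% in this assay, at which 1 of the 4 values shown sits.

Phenyl is the only ring shown at this position, so it remains unclear whether the fall belongs to an aromatic ring or to any ring. A cyclohexyl group would address that question, while a phenylethyl group would show whether the fall persists when the ring sits farther along a longer chain.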